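This account rests on a few compounds, and the source may have more. Where it says the series, first, only, none or still open, it means among the compounds named here.

Measured compounds in this study:
compound 1 `COCOc1cc(C2=C(c3cc(OC)c(OC)c(OC)c3)C(=O)CC2O[SiH2]C(C)(C)C)ccc1OC`, with 43 ug/mL.
compound 2 `COc1cc(C2=C(c3cc(C)c(OC)c(C)c3)C(O)CC2=O)cc(OC)c1OC`, for which only a limit of the assay is given, > 100 ug/mL.
compound 3 `C=CCOc1cc(C2=C(c3cc(OC)c(OC)c(OC)c3)C(=O)C(O)C2)ccc1OC`, for which again only a limit is given, > 100 ug/mL.

For the measured compounds named here, in an ADME assay on HT-29 cells (Homo sapiens) for cytotoxicity, read by MTT assay, with a stated time of 72 h (a higher number here means a weaker inhibitor, a lower number a stronger inhibitor), compound 1 gives 43 ug/mL, the only number among the three results. Going by the values given here, the other two compounds sit at the limit of > 100 ug/mL in this assay, at which 2 of the 3 values shown sit, so compound 1 stands alone as the one with a measured inhibitory concentration, and no step between two measured compounds can be read from these data.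

Compound 4 `COc1ccc(C2=C(c3cc(OC)c(OC)c(OC)c3)C(=O)CC2O[SiH2]C(C)(C)C)cc1` differs from compound 1 in one place: hydrogen in place of methoxymethoxy on an aromatic carbon. The methoxymethoxy group is removed and nothing takes its place but hydrogen, while the rest of the shared core of compound 1 is kept.

Among the compounds with values here, with no measured step to lean on, the expectation for compound 4 rests on compound 1 alone. The step of a 1.4-fold higher number from compound 1 to compound 4 (0.14 log units; within the scatter) is expected to be small, not clearly beyond the scatter, perhaps leaning toward a weaker inhibitor. Compound 4 is therefore estimated at 60 ug/mL, within a range from 20 ug/mL to 150 ug/mL.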

Compound 4, half-maximal inhibitory concentration: > 100 ug/mL
Compound 4 was reported as a limit; the forecaster's own chance of this, stated with the estimate: 30%; middle value at least 1.6-fold (0.22 log units) from the limit.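

In this assay, for the compounds shown here, the methoxymethoxy group of compound 1 proves not to be dispensable: putting hydrogen in its place gives an at least 2.3-fold higher number from compound 1 to compound 4 (0.36 log units; beyond the scatter) and is the first step in this set that can be read. Going by these compounds alone, this change on the aromatic carbon ortho to a methoxy group is thus the one place so far where a change is seen to matter. Going by these compounds, the result for compound 4 is a limit of the assay and not a number, so the full size of the step stays unknown, and that limit is a common one here: the limit of > 100 ug/mL in this assay, at which 3 of the 4 values shown sit.

The compounds shown leave open whether another group at this position, such as a hydroxyl, an amine or a longer alkoxy chain, would match compound 1 or improve on it. They also leave open whether the same replacement would matter with the rest of the shared core changed.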